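The source may hold more compounds than are shown below. What is called first, only, known or untested is meant among the compounds shown, and "the series" means these compounds.

Measured in a physicochemical assay for lipophilicity, in phosphate buffer, measured as octanol-water partition, at pH 11.5; a higher number here means a more lipophilic compound, a lower number a more polar compound:
Compound 1 `CCCCCCCCCCOC(=N)NC(=N)Nc1ccc(Cl)cc1`: 6.32
Compound 2 `CCCS(=O)(=O)c1ccc(NC(=N)NC(=N)NCCCCCCNC(=N)NC(=N)Nc2ccc(S(=O)(=O)CCC)cc2)cc1`: 2.1

Of these two, compound 1 stands higher, at 6.32, while compound 2 gives 2.1, a gap beyond the usual scatter. Compound 3 `CCCCCCOC(=N)NC(=N)Nc1ccc(Cl)cc1` has not yet been measured. It departs from compound 1 in one place: hydrogen in place of butyl on a saturated chain carbon, six bonds along the chain from an oxygen on an unsaturated carbon. This puts hydrogen in place of butyl on a saturated chain carbon, six bonds along the chain from an oxygen on an unsaturated carbon. Among the compounds with values here, no measured pair differs in one place only, so the expectation rests on the structural change alone. A fall beyond the scatter is expected in this assay. The estimated change is a number 2.02 log units lower from compound 1 to compound 3 (beyond the scatter). The expected value for compound 3 is 4.3, with an estimated range from 3.6 to 5.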

Compound 3, partition coefficient: 4.32
Compound 3: middle estimate off by 0.02 log units, on the low side; low and high end bracket the measured number.
By their numbers in this assay, from the lowest: compound 2; then compound 3; then compound 1.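

In this assay, the change of butyl to hydrogen on a saturated chain carbon, six bonds along the chain from an oxygen on an unsaturated carbon, gives a number 2.00 log units lower from compound 1 to compound 3 (beyond the scatter). Within the data shown here, this is the first reading of a single change at this position, as the gap between compound 1 and compound 2 spans differences in more than one place and could not be tied to the chain alone. The step shows that this all-carbon part of the chain, with no ring and no net charge, carries a large share of the number for compound 1, but no independent measurement bears on why the number moves.

As far as these compounds go, a single step gives only its two ends, so it remains open whether the fall is spread evenly along the chain or whether a longer chain would extend it. Also open, from the compounds shown here alone, is how an amine or a carboxylic acid on this chain carbon would read in this assay.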